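This account rests on a few compounds, and the source may have more. Where it says the series, first, only, none or still open, it means among the compounds named here.

Compound 3 `O=c1cc(CCl)c2ccc(OCc3cccc(Cl)c3)cc2o1` gives 21% in an assay on isolated protein (strain Sprague-Dawley) for inhibition of Amine oxidase [flavin-containing] A (Rattus norvegicus), read by spectrophotometry, with a stated time of 5 min, tested at 10 uM; on this read-out lower numbers stand for less inhibition and higher numbers for more inhibition at the one concentration tested (going by the name of the read-out). Compound 1 `CNC(=O)COc1cc(=O)oc2cc(OCc3cccc(Cl)c3)ccc12` gives 11%, and compound 2 `CCNC(=O)Nc1cc(=O)oc2cc(OCc3cccc(Cl)c3)ccc12` gives 0%. Compound 3 thus stands beyond the scatter above compound 2, with a number 21 percentage points higher from compound 2 to compound 3 (beyond the scatter), while its distance from compound 1, a number 10 percentage points higher from compound 1 to compound 3 (within the scatter), lies within the scatter. Compound 4 `N#Cc1cc(=O)oc2cc(OCc3cccc(Cl)c3)ccc12` carries cyano in place of chloromethyl on an aromatic carbon. The measured steps that bear on this change are the two that end at compound 3 by exchanging the group on that same carbon: a number 10 percentage points higher from compound 1 to compound 3 (within the scatter), a change within the scatter, and a number 21 percentage points higher from compound 2 to compound 3 (beyond the scatter), a modest change beyond it. For the measured compounds named here, both put chloromethyl in place of (methylcarbamoyl)methoxy or (ethylcarbamoyl)amino; no measured pair contains cyano, so the direction of the new step is not fixed by the data. Because compound 1 gave 11% and compound 2 gave 0% with the other groups tried on this carbon, a small drop is expected. For compound 4 that means an expected step of about a number 6 percentage points lower from compound 3 to compound 4 (within the scatter), staying within the scatter. Compound 4 is therefore estimated at 15%, with a range from 0% to 35%.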

Compound 4, a percentage reported as inhibition, at one concentration (the size of the read-out at that concentration, not a potency): 23%
Beside the measured number, compound 4's estimate is 8 percentage points below it, and the stated range covers the measured number.
By their numbers in this assay, from the lowest: compound 2; then compounds 1, 3 and 4 (each within the scatter of the next, the first and the last beyond it).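

In this assay, cyano in place of chloromethyl on this aromatic carbon, opposite the ring oxygen, gives no change that can be told from the scatter (a number 2 percentage points higher from compound 3 to compound 4 (within the scatter)), so the chlorine of chloromethyl is not required to keep the number at the level of compound 3. Cyano also stands clear of both carbamoyl-bearing groups tried on this carbon (a number 23 percentage points higher from compound 2 to compound 4 (beyond the scatter); a number 12 percentage points higher from compound 1 to compound 4 (beyond the scatter)), whereas chloromethyl stood clear of only (ethylcarbamoyl)amino. Nothing available gives a reason for this ordering of the groups.

On these data alone, whether an amine, a carboxylic acid or a longer alkyl chain on this carbon would raise the number remains open. Also open, as far as these compounds go, is whether cyano and chloromethyl would separate at any other concentration, since each compound here was read at a single one.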